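A few compounds are considered here, and "the series" means these few. Any claim that something is new, unique, unknown or untested is made for them only; others in the source may bear on it.

Compound 1 `CN1C(=O)NC2(CC2(C)C)C1=O`: 60%
Compound 2 `CCCCN1C(=O)NC2(CC2(C)C)C1=O`: 60%

In a functional assay on the whole organism for inhibition, with Mus musculus as the target, at a dose of 80 mg/kg by the oral route (on this read-out lower numbers stand for a weaker effect and higher numbers for a stronger effect at the one dose given), compound 1 gives 60% and compound 2 gives 60%, so compound 2 stands level with compound 1 within the usual scatter. Among the measured compounds shown here, the single measured step, no change at the digits printed from compound 1 to compound 2 (within the scatter), shows a read-out that did not move. Compound 3 `CCC(CO)N1C(=O)NC2(CC2(C)C)C1=O` differs from compound 2 as follows: 1-(hydroxymethyl)propyl in place of butyl on an amide-type nitrogen in a ring. For the measured compounds named here, only that one flat step bears on this change, so no shift beyond the scatter is expected, the expected step being a number 2 percentage points lower from compound 2 to compound 3 (within the scatter). Compound 3 is estimated at 58%, within a range from 40% to 75%.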

Compound 3, a percentage reported as inhibition, in the whole organism at one dose (the size of the read-out at that dose, not a potency): 70%
The estimate for compound 3 lay 12 percentage points below the measured number; the measured number falls inside the stated range.
By their numbers in this assay, from the lowest: compounds 1, 2 and 3 (each within the scatter of the next).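

At this amide-type nitrogen in a ring, 1-(hydroxymethyl)propyl in place of butyl gives a number 10 percentage points higher from compound 2 to compound 3 (within the scatter) in this assay, and in place of methyl it gives a number 10 percentage points higher from compound 1 to compound 3 (within the scatter). Among the compounds shown here, the position therefore keeps the read-out with a branched chain carrying oxygen, whereas the earlier compounds showed only the unbranched methyl and butyl chains. Nothing available explains this result. From the compounds shown here alone, whether an amine or a carboxylic acid in place of the hydroxyl would also keep the read-out remains open. A single dose also shows only the size of the effect at that dose.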